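The source may report more compounds than this note shows. Statements on the series, on what has been measured and on what is new or still open speak of the compounds shown alone.

Measured so far, in a functional assay on CV-1 cells for agonist activity at Bile acid receptor (Homo sapiens), read by a luciferase reporter; on this read-out lower numbers stand for an effect already at smaller amounts and higher numbers for an effect only at larger amounts of compound:
- compound 3 `CC(C)c1onc(-c2c(Cl)cccc2Cl)c1COc1ccc(-c2ccc3sc(C(=O)O)cc3c2)cc1`, 530 nM
- compound 1 `CC(C)c1onc(-c2c(Cl)cccc2Cl)c1COc1ccc(-c2ccc3c(c2)CCCC3C(=O)O)cc1`, 750 nM
- compound 2 `CC(C)c1onc(-c2c(Cl)cccc2Cl)c1COc1ccc(Sc2cccc3sc(C(=O)O)cc23)cc1`, 990 nM

All three share the same core and differ in the acid-bearing ring system attached to the phenoxy group. Compound 3 has the lowest of the three numbers in this assay, yet its gap to compound 1 and its gap to compound 2 both lie within the usual scatter, so the three compounds cannot be told apart on these data.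

Compound 4 `CC(C)c1onc(-c2c(Cl)cccc2Cl)c1COc1ccc(-c2ccc3sc(C(=O)O)cc3n2)cc1` has not been measured. It differs from compound 3 in one place: a group of 12 heavy atoms (8 carbon, 1 nitrogen, 2 oxygen, 1 sulfur; one five-membered aromatic ring with 1 hetero atom, one six-membered aromatic ring with 1 hetero atom) in place of a group of 12 heavy atoms (9 carbon, 2 oxygen, 1 sulfur; one five-membered aromatic ring with 1 hetero atom, one six-membered aromatic ring of carbon only), on an aromatic carbon. Going by the values given here, no measured pair in this set shows the effect of putting a nitrogen into that six-membered ring, so the expectation rests only on the closeness of the three values seen so far, which vary little across rather larger changes of the acid-bearing part. The step from compound 3 to compound 4 is therefore expected to be small, most likely toward a somewhat higher number, a 1.5-fold higher number from compound 3 to compound 4 (0.18 log units; within the scatter). In this assay compound 4 is estimated at 800 nM, within a range of 300 nM to 2500 nM.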

Compound 4, half-maximal effective concentration: 1700 nM
Beside the measured number, compound 4's estimate is 2.1-fold (0.33 log units) below it; low and high end bracket the measured number.
By their numbers in this assay, from the lowest: compounds 3, 1, 2 and 4 (each within the scatter of the next, the first and the last beyond it).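

In this assay, replacing the 2-carboxy-1-benzothiophen-5-yl group with its counterpart bearing a nitrogen in the six-membered aromatic ring gives a 3.2-fold higher number from compound 3 to compound 4 (0.51 log units; beyond the scatter) and so moves the read-out toward larger amounts of compound. Going by these compounds alone, this is the first comparison here between compounds that differ in one place, and it shows that this part of the molecule is not indifferent to change: a ring nitrogen alone, with the heavy-atom count of the group unchanged, gives a step beyond the scatter. Nothing available here explains this step.

As far as these compounds go, it remains open whether a nitrogen elsewhere in that six-membered ring would give a similar step. From the compounds shown here alone, it is equally open how a fluorine or a methoxy group on that ring would compare with compound 3 in this assay on this read-out.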